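Clearance notes: from compound 3 to compound 4

The compounds below may be only part of what the source reports. "The series", "measured", "known", "first", "only" and "open" are said of these compounds alone.

Measured in an ADME assay on microsomes from liver (Homo sapiens) for metabolic stability, read by LC-MS, using NADPH, with stated times of 5 min and 30 min, tested at 1 uM; on this read-out higher numbers stand for fast clearance and lower numbers for slow clearance:
compound 1 `O=C1CCCN1c1cnc(NCc2c(F)ccc3c2CCO3)c2cn[nH]c(=O)c12`: 23 mL.min-1.g-1
compound 2 `Cc1cc(-c2cnc(NCc3c(F)ccc4c3CCO4)c3cn[nH]c(=O)c23)n(C)n1`: 24 mL.min-1.g-1
compound 3 `Cc1ncccc1-c1cnc(NCc2c(F)ccc3c2CCO3)c2cn[nH]c(=O)c12`: 41 mL.min-1.g-1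

Compound 3 gives 41 mL.min-1.g-1 and does not separate from the other two: a 1.8-fold higher number from compound 1 to compound 3 (0.25 log units; within the scatter) and a 1.7-fold higher number from compound 2 to compound 3 (0.23 log units; within the scatter) both lie within the scatter. The next structure is compound 4 `Cc1nn(C)cc1-c1cnc(NCc2c(F)ccc3c2CCO3)c2cn[nH]c(=O)c12`, and the difference is 1,3-dimethyl-1H-pyrazol-4-yl in place of 2-methylpyridin-3-yl on an aromatic carbon. The closest measured step is a 1.7-fold higher number from compound 2 to compound 3 (0.23 log units; within the scatter), where 2-methylpyridin-3-yl replaces 1,3-dimethyl-1H-pyrazol-5-yl. The remaining step, a 1.0-fold higher number from compound 1 to compound 2 (0.02 log units; within the scatter), also stays within the scatter. None of these steps leaves the scatter, so none beyond it is expected in this assay. The expected change is a 1.5-fold lower number from compound 3 to compound 4 (0.17 log units; within the scatter). For compound 4 the estimated value is 28 mL.min-1.g-1, with an expected range of 15 mL.min-1.g-1 to 50 mL.min-1.g-1.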

Compound 4, intrinsic clearance in microsomes: 27 mL.min-1.g-1
Compound 4: the middle estimate sits 1.0-fold (0.02 log units) above what was measured; the range from low to high includes it.
By their numbers in this assay, from the lowest: compounds 1, 2, 4 and 3 (each within the scatter of the next).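

In this assay, the change from 2-methylpyridin-3-yl to 1,3-dimethyl-1H-pyrazol-4-yl, a six-membered aromatic ring giving way to a five-membered one, does not leave the scatter: a 1.5-fold lower number from compound 3 to compound 4 (0.18 log units; within the scatter). Moving the same dimethylpyrazole to its other attachment gives a 1.1-fold higher number from compound 2 to compound 4 (0.05 log units; within the scatter), and the comparison with 2-oxopyrrolidin-1-yl gives a 1.2-fold higher number from compound 1 to compound 4 (0.07 log units; within the scatter), so all four groups at this position remain unseparated. Nothing measured here explains these values. Still open, going by these compounds, is whether any group on this aromatic carbon moves clearance beyond the scatter, such as an amine, a carboxylic acid or a longer alkyl chain.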